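A Trifluoromethoxyphenyl Variant Tested Against GMP Reductase 2

The source may report more compounds than this note shows. Statements on the series, on what has been measured and on what is new or still open speak of the compounds shown alone.

Three compounds of a shared amide series have been examined in an assay on isolated protein for inhibition of GMP reductase 2 (Homo sapiens), read by spectrophotometry; on this read-out higher numbers stand for weaker inhibition and lower numbers for stronger inhibition. Compound 1 `COc1ccc(OC(C)C(=O)Nc2ccc3oc(-c4ccncc4)nc3c2)cc1` returns only the limit of the read-out, giving > 5000 nM. Compound 2 `C[C@H](Oc1cccc(Cl)c1Cl)C(=O)Nc1ccc2oc(C3=CC=NCC3=O)nc2c1` likewise stops at a limit, with > 5000 nM. Compound 3 `C[C@H](Oc1cccc(F)c1F)C(=O)Nc1ccc2oc(-c3ccc(F)cc3)nc2c1`, which carries a fluorinated phenyl group, also reaches only a limit, reported as > 5000 nM. Compound 2 therefore has no distinct standing among the numbers shown: it sits at the limit of > 5000 nM in this assay, at which 3 of the 3 values shown sit, and since every value is a limit, no ordering among the three can be read off. Among the measured compounds shown here, no two measured compounds differ in a single place, so no measured step is available.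

Compound 4 `C[C@H](Oc1cccc(Cl)c1Cl)C(=O)Nc1ccc2oc(-c3ccc(OC(F)(F)F)cc3)nc2c1` is the unmeasured partner of compound 2. The change is a group of 11 heavy atoms (7 carbon, 1 oxygen, 3 fluorine; one six-membered aromatic ring of carbon only) in place of a group of 7 heavy atoms (5 carbon, 1 nitrogen, 1 oxygen; one six-membered non-aromatic ring with 1 hetero atom), on an aromatic carbon, the 4-(trifluoromethoxy)phenyl taking the place of the six-membered non-aromatic ring with one hetero atom on the aromatic carbon of the five-membered aromatic ring. With compound 3 showing that a substituted phenyl at that carbon also ends at a limit, the step from compound 2 to compound 4 is expected to be none beyond the scatter, as a step that the limit leaves unreadable from compound 2 to compound 4 states. Compound 4 is estimated at 8000 nM, within a range from 3000 nM to 30000 nM, and most probably reported once more only as a limit.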

Compound 4, inhibition constant: > 5000 nM
Compound 4: only a limit was reported (the forecaster's own chance of this, stated with the estimate: 75%); the middle value does not contradict the limit.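

Compound 4 gives > 5000 nM, which is again only a limit. No step can be read between compound 2 and compound 4, since both end at a limit, and the whole set now stands together: the limit of > 5000 nM in this assay, at which 4 of the 4 values shown sit. The compounds shown leave open whether any member of this series returns a number rather than a limit.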